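The compounds below may be only part of what the source reports. "The series", "measured", "known", "first", "only" and "open" are said of these compounds alone.

In a functional assay on SK-BR-3 cells (Homo sapiens) for antiproliferative activity, read by luminescence, with a stated time of 72 h (a lower number here means a stronger inhibitor, a higher number a weaker inhibitor), so far:
compound 1 `CN1CC=C(c2c(O)cc(O)c3c(=O)cc(-c4ccc(Sc5nc6ccccc6[nH]5)cc4)oc23)CC1` gives 254 nM
compound 2 `CN1CC=C(c2c(O)cc(O)c3c(=O)cc(-c4ccc(Sc5nc6ccccc6n5C)cc4)oc23)CC1` gives 249 nM

Among the measured compounds shown here, compound 2 at 249 nM stands level with compound 1 within the scatter, and these are the only two numbers. Compound 3 `CN1CC=C(c2c(O)cc(O)c3c(=O)cc(-c4ccc(Sc5nc(-c6ccccc6)c[nH]5)cc4)oc23)CC1` carries a new group on the sulfur, with 4-phenyl-1H-imidazol-2-yl in place of 1-methyl-1H-benzimidazol-2-yl, and 4-phenyl-1H-imidazol-2-yl in place of 1-methyl-1H-benzimidazol-2-yl on a sulfur gives the count of that change. For the measured compounds named here, the one measured step, a 1.0-fold lower number from compound 1 to compound 2 (0.01 log units; within the scatter) for methyl in place of hydrogen on an aromatic nitrogen, stays within the scatter and does not exchange the group as a whole, so it sets no size for this change. In this assay a moderate step of uncertain direction is therefore expected, leaning slightly to a higher number. The estimated step is a 1.3-fold higher number from compound 2 to compound 3 (0.11 log units; within the scatter) on this reading. For compound 3 the expected value is 320 nM with 100 nM as the estimated lower end and 1000 nM as the estimated upper end.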

Compound 3, half-maximal inhibitory concentration: 352 nM
Compound 3: middle estimate off by 1.1-fold (0.04 log units), on the low side, and the stated range covers the measured number.
By their numbers in this assay, from the lowest: compounds 2, 1 and 3 (each within the scatter of the next).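

On the sulfur, the whole group can now be exchanged rather than only methylated on its aromatic nitrogen: in this assay, 4-phenyl-1H-imidazol-2-yl in place of 1-methyl-1H-benzimidazol-2-yl gives a 1.4-fold higher number from compound 2 to compound 3 (0.15 log units; within the scatter), and 4-phenyl-1H-imidazol-2-yl in place of 1H-benzimidazol-2-yl gives a 1.4-fold higher number from compound 1 to compound 3 (0.14 log units; within the scatter). Compound 1, compound 2 and compound 3 therefore stand level, so this position accepts a different group carrying one five-membered and one six-membered aromatic ring, with one more heavy atom and one hydrogen-bond donor in place of an acceptor relative to 1-methyl-1H-benzimidazol-2-yl. No measurement at hand bears on why the numbers stay level.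

Still open, as far as these compounds go, is whether this level holds for a group on the sulfur without aromatic rings, such as a short chain ending in an amine or a carboxylic acid. Also open, from the compounds shown here alone, is whether substituents on the phenyl of 4-phenyl-1H-imidazol-2-yl, such as methoxy or chloro, move the number beyond the scatter.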